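Swapping a Chlorophenyl for a Cyanophenyl: Cytotoxicity Outlook

The source may hold more compounds than are shown below. What is called first, only, known or untested is meant among the compounds shown, and "the series" means these compounds.

Compound 1 `Cc1cccc(-c2cccc(NCc3cncn3Cc3ccccc3)c2)c1C`: > 1000 nM
Compound 2 `COC(=O)c1ccc(NCc2cncn2Cc2cccc(Cl)c2)cc1-c1ccccc1`: > 10000 nM
Compound 3 `CC(C)OC(=O)c1ccc(NCc2cncn2Cc2ccc(-c3ccccc3)cc2)cc1-c1ccccc1`: > 10000 nM

In a toxicity assay on NIH3T3 cells (Mus musculus) for cytotoxicity, read by resazurin assay (a lower number here means that less compound is needed, a higher number that more compound is needed for the effect), compound 2 gives > 10000 nM, which is a limit of the assay and not a measured number. Compound 3 likewise sits at a limit, > 10000 nM. Compound 1 sits at a different limit, > 1000 nM. Two of the three values therefore share (the limit of > 10000 nM in this assay, at which 2 of the 3 values shown sit), while one sits at the limit of > 1000 nM in this assay, at which 1 of the 3 values shown sits. No pair of these compounds differs in a single place, so no measured step is available.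

Compound 4 `COC(=O)c1ccc(NCc2cncn2Cc2ccccc2C#N)cc1-c1ccccc1` is not yet measured. It differs from compound 2 as follows: 2-cyanophenyl in place of 3-chlorophenyl on a saturated chain carbon bound to an aromatic nitrogen. The expectation is no step beyond the scatter, so compound 4 is expected to give 20000 nM, with a range from 10000 nM to 100000 nM. The estimated step that the limit leaves unreadable from compound 2 to compound 4 is expected to stay within the scatter.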

Compound 4, half-maximal effective concentration: 25000 nM
Compound 4: the middle estimate sits 1.3-fold (0.10 log units) below what was measured; measured number inside the range.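

Going by these compounds alone, no step from compound 2 to compound 4 can be read, because the value of compound 2 is only a limit: the limit of > 10000 nM in this assay, at which 2 of the 4 values shown sit.

The compounds shown leave open whether 2-cyanophenyl and 3-chlorophenyl differ at all in this assay.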